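Methoxycarbonyl to carboxy on compound 2

The source may report more compounds than this note shows. Statements on the series, on what has been measured and on what is new or still open speak of the compounds shown alone.

Measured so far in a functional assay on corpus cavernosum (Rattus norvegicus) for activation (on this read-out lower numbers stand for an effect already at smaller amounts and higher numbers for an effect only at larger amounts of compound), are two compounds
- Compound 1 `CCCCOc1ccccc1-c1nc2c(cnn2-c2ccc(Br)cc2)c(=O)[nH]1` gives 4.89 nM
- Compound 2 `COC(=O)c1ccccc1OCc1nc2c(cnn2-c2ccccc2)c(=O)[nH]1` gives 100 nM

Compound 2 stands at the higher number of the two, and its gap to compound 1 lies beyond the scatter. Compound 3 `O=C(O)c1ccccc1OCc1nc2c(cnn2-c2ccccc2)c(=O)[nH]1` differs from compound 2 in one place, (hydrogen in place of methyl on an oxygen next to a carbonyl group), with hydrogen in place of methyl on an oxygen next to a carbonyl group, or methoxycarbonyl to carboxy. Going by the values given here, no measured pair shows this change, and compounds 1 and 2 differ in more than one place, so the expectation is a judgement. Starting from compound 2 at 100 nM, a moderate move towards a higher number is expected in this assay, with the estimated step of a 3.0-fold higher number from compound 2 to compound 3 (0.48 log units; beyond the scatter) beyond the scatter. For compound 3 the expected value is 300 nM, with an estimated range from 60 nM to 1500 nM as the working figure.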

Compound 3, half-maximal effective concentration: 223 nM
The estimate for compound 3 lay 1.3-fold (0.13 log units) above the measured number, and the stated range covers the measured number.
By their numbers in this assay, from the lowest: compound 1; then compound 2; then compound 3.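

In this assay, going by these compounds alone, methoxycarbonyl to carboxy, with hydrogen in place of methyl on an oxygen next to a carbonyl group, gives a 2.2-fold higher number from compound 2 to compound 3 (0.35 log units; beyond the scatter) as the first single-place step. This position therefore accepts the carboxy group at a modest cost, and the loss of one methyl does not abolish activation on this read-out. Nothing available bears on the reason for this step.

Still open, going by these compounds, is how a primary amide or an ethyl ester in the same place would rank against compound 2 and compound 3. Compound 1 differs from compound 2 in more than one place, so the separate contributions of its butoxy group and bromine remain unresolved, as does whether the methyl-to-hydrogen step would recur on that compound.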